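The compounds below may be only part of what the source reports. "The series", "measured", "known", "first", "only" and "open" are said of these compounds alone.

Compound 1, `CCc1cc(C(C)=O)c(O)cc1OCCCCCCC#N`, gives 103% in an assay on isolated protein for inhibition of leukotriene B4 receptor 1 (Homo sapiens), tested at 10 uM; on this read-out higher numbers stand for more inhibition at the one concentration tested (going by the name of the read-out) and lower numbers for less inhibition.
Compound 2, `CCc1cc(C(C)=O)c(O)cc1OCCCCCC(C)(C)C#N`, gives 85% in this assay.
Compound 3, `CCc1cc(C(C)=O)c(O)cc1OCCCCCCC(C)(C)C#N`, gives 65% in this assay.

Compound 3 stands lowest of the three in this assay; its nearest neighbour is compound 2, whose value lies a number 20 percentage points lower from compound 2 to compound 3 (beyond the scatter), and the furthest is compound 1, with a number 38 percentage points lower from compound 1 to compound 3 (beyond the scatter). The step from compound 1 to compound 2 was a number 18 percentage points lower from compound 1 to compound 2 (beyond the scatter). Compound 4, `CCc1cc(C(C)=O)c(O)cc1OCCCC(C)(C)C(N)=O`, is not yet measured. It differs from compound 3 as follows: 1-carbamoyl-1-methylethyl in place of 4-cyano-4-methylpentyl on a saturated chain carbon, three bonds along the chain from an oxygen on an aromatic ring. Within the data shown here, none of the measured steps swaps the nitrile for a carbamoyl group, so no step bears directly on that part of the change; only the shortening of the chain has a counterpart, in the step from compound 2 to compound 3, where the longer chain gave the lower number. On that basis a modest rise is expected for compound 4 in this assay, namely a number 7 percentage points higher from compound 3 to compound 4 (within the scatter), though the nitrile-to-carbamoyl change leaves this uncertain. Compound 4 is therefore estimated at 72%, between 40% and 100%.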

Compound 4, a percentage reported as inhibition, at one concentration (the size of the read-out at that concentration, not a potency): 92%
Compound 4: the middle estimate sits 20 percentage points below what was measured; measured number inside the range.
By their numbers in this assay, from the lowest: compound 3; then compounds 2 and 4 (each within the scatter of the next); then compound 1.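

The swap of 4-cyano-4-methylpentyl for 1-carbamoyl-1-methylethyl, on a saturated chain carbon, three bonds along the chain from an oxygen on an aromatic ring, gives a number 27 percentage points higher from compound 3 to compound 4 (beyond the scatter) in this assay and shows that a nitrile is not required for a high reading among these compounds. Replacing 3-cyano-3-methylbutyl at this place gives a number 7 percentage points higher from compound 2 to compound 4 (within the scatter) and so leaves the reading level, whereas replacing 3-cyanopropyl gives a number 11 percentage points lower from compound 1 to compound 4 (beyond the scatter) and leaves compound 1 apart from compound 4. No measurement at hand explains these differences.

Chain length and end group change together in these steps, so their separate shares remain unresolved. Also open, going by these compounds, is what a nitrile, a carboxylic acid or an amine would give at the end of the chain of compound 4.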